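The source may hold more compounds than are shown below. What is called first, only, known or untested is meant among the compounds shown, and "the series" means these compounds.

Measured compounds:
- compound 1, `O=C(CCCCCCCCCCc1ccccc1)CC(=O)N[C@H]1CCOC1=O`: 23000 nM
- compound 2, `O=C(CCCCCCCCCc1ccccc1)CC(=O)N[C@H]1CCOC1=O`: 16000 nM
- compound 3, `O=C(CCCCCCCc1ccccc1)CC(=O)N[C@H]1CCOC1=O`: 42000 nM

These three compounds share a core and differ only in how far the terminal aromatic ring sits from the chain carbonyl. In a functional assay on NCI-H630 cells (Homo sapiens) for cytotoxicity, read by sulforhodamine B assay, with a stated time of 5 days (a lower number here means a stronger inhibitor, a higher number a weaker inhibitor), compound 3 gives the highest number of the three. Its step from compound 1 is a 1.8-fold higher number from compound 1 to compound 3 (0.26 log units; within the scatter), while the step from compound 2 is a 2.6-fold higher number from compound 2 to compound 3 (0.42 log units; beyond the scatter); compound 1 and compound 2 differ by a 1.4-fold lower number from compound 1 to compound 2 (0.16 log units; within the scatter).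

Compound 4, `O=C(CCCCCc1ccccc1)CC(=O)N[C@H]1CCOC1=O`, has not yet been measured. It differs from compound 3 in one place: phenyl in place of phenethyl on a saturated chain carbon, five bonds along the chain from a carbonyl carbon. This is the same kind of change as that from compound 2 to compound 3, only one position nearer the carbonyl. The steps seen so far point the same way: each shortening of the chain gave a higher number, one of them beyond the scatter, the others within it. A modest rise in this assay is therefore expected for compound 4, with the chance that it stays within the scatter of compound 3 or that the assay reports only a limit.

The expected step from compound 3 to compound 4 is a 1.9-fold higher number from compound 3 to compound 4 (0.28 log units; within the scatter). Compound 4 is estimated at 80000 nM, with a range from 30000 nM to 200000 nM.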

Compound 4, half-maximal inhibitory concentration: 44000 nM
Compound 4: middle estimate off by 1.8-fold (0.26 log units), on the high side, and the stated range covers the measured number.
By their numbers in this assay, from the lowest: compounds 2, 1, 3 and 4 (each within the scatter of the next, the first and the last beyond it).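

In this assay, phenyl in place of phenethyl on a saturated chain carbon, five bonds along the chain from a carbonyl carbon, leaves the reading level (a 1.0-fold higher number from compound 3 to compound 4 (0.02 log units; within the scatter)), so at this place the swap produces nothing that can be told apart from the ordinary scatter of repeat measurements. The same kind of swap seven bonds along the chain gave a step beyond the scatter (a 2.6-fold higher number from compound 2 to compound 3 (0.42 log units; beyond the scatter)), so among these compounds the outcome of this change depends on where along the chain it is made, and compound 4 goes against the earlier impression that each shortening gives a higher number. Nothing measured here accounts for the difference between these two places.

The compounds shown leave open whether a still shorter chain would also stay level with compound 3 or would finally shift the number. They also leave open whether an amine or a carboxylic acid in place of phenyl would change the reading, since every chain here ends in the same unsubstituted aromatic ring.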